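Hydrogen for Fluoro on the Distal Aryl Ring

The source may report more compounds than this note shows. Statements on the series, on what has been measured and on what is new or still open speak of the compounds shown alone.

Measured so far:
Compound 1 `COc1cccc(CNCCCNc2ccnc3cc(-c4ccc(F)cc4)ccc23)c1O` — 9.47
Compound 2 `COc1ccc(F)cc1CNCCCNc1ccnc2cc(-c3ccc(F)cc3)ccc12` — 9.47
Compound 3 `c1coc(CNCCCNc2ccnc3cc(CC4CCCCC4)ccc23)c1` — 9.47

In a physicochemical assay for acid dissociation, compound 1 gives 9.47, level with compounds 2 and 3 at the digits shown. Among the measured compounds shown here, the one measured step, no change at the digits printed from compound 1 to compound 2 (within the scatter), concerns the group on the saturated chain carbon bound to the amine nitrogen and lies within the scatter. Compound 4 `COc1cccc(CNCCCNc2ccnc3cc(-c4ccccc4)ccc23)c1O` differs from compound 1 by hydrogen in place of fluoro on an aromatic carbon. For the measured compounds named here, no measured step touches this fluoro; the flat step to compound 2 and the matching reading of compound 3, whose core carries a different group, give no sign of movement anywhere. Compound 4 is therefore expected at 9.47, with a range from 9.2 to 9.75. The expected step is no change at the digits printed from compound 1 to compound 4 (within the scatter), none beyond the scatter.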

Compound 4, acid dissociation constant: 9.47
The estimate for compound 4 equals the measured number at the digits printed; the range from low to high includes it.
By their numbers in this assay, from the lowest: compounds 1, 2, 3 and 4 (each within the scatter of the next).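

In this assay, among the compounds shown here, the change from 4-fluorophenyl to phenyl gives the first measured step at this position (no change at the digits printed from compound 1 to compound 4 (within the scatter)). For this pair, fluoro and hydrogen on this aromatic carbon therefore read alike, a point the earlier step, made elsewhere in the molecule, could not address. No supporting data bear on why the reading holds.

On these data alone, whether a larger group in this place, such as a carboxylic acid, an amine or a longer chain, would shift the reading remains open. Also open, as far as these compounds go, is whether the same exchange reads alike with the 5-fluoro-2-methoxyphenyl group of compound 2.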